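Cyano in place of methyl on the pendant phenyl

The source may report more compounds than this note shows. Statements on the series, on what has been measured and on what is new or still open speak of the compounds shown alone.

Compound 3 `Cc1ccc(-c2c(C)cccc2C(=O)Nc2ccc3c(c2)CC(NS(=O)(=O)c2ccccc2)C3)cc1` gives 2.5 nM in an assay for inhibition of apolipoprotein B-100 (Homo sapiens), tested at 100 nM; a higher number here means a weaker inhibitor, a lower number a stronger inhibitor. Its nearest neighbour in this assay is compound 1 `COC(=O)N[C@H]1Cc2ccc(NC(=O)c3ccccc3-c3ccc(C(F)(F)F)cc3)cc2C1`, which gives 1.9 nM on a different core; the gap between the two lies within the scatter. The furthest is compound 2 `Cc1cccc(C(=O)Nc2ccc3c(c2)CC(NS(=O)(=O)c2ccccc2)C3)c1-c1ccc(F)cc1`, which gives 1.2 nM, and the step of a 2.1-fold higher number from compound 2 to compound 3 (0.32 log units; beyond the scatter) is the only one in the set that lies beyond the scatter.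

Compound 4 `Cc1cccc(C(=O)Nc2ccc3c(c2)CC(NS(=O)(=O)c2ccccc2)C3)c1-c1ccc(C#N)cc1` differs from compound 3 by cyano in place of methyl on an aromatic carbon; cut one bond further out, this reads 4-methylphenyl to 4-cyanophenyl. For the measured compounds named here, no measured step exchanges methyl for cyano. Going by the values given here, the one step that touches the same aromatic carbon, a 2.1-fold higher number from compound 2 to compound 3 (0.32 log units; beyond the scatter), shows that swapping the group there moves the number only modestly, and compound 1, carrying trifluoromethyl at the corresponding place on its own core, gives 1.9 nM and also stays close to the rest. For compound 4, the expected step is a 1.3-fold lower number from compound 3 to compound 4 (0.10 log units; within the scatter), a small move toward a lower number that may well stay within the scatter. For compound 4 the estimate in this assay is 2 nM, with a range from 0.8 nM to 5 nM.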

Compound 4, half-maximal inhibitory concentration: 5.5 nM
Compound 4: the middle estimate sits 2.8-fold (0.44 log units) below what was measured; the measured number lies above the stated range.
By their numbers in this assay, from the lowest: compounds 2, 1 and 3 (each within the scatter of the next, the first and the last beyond it); then compound 4.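

Cyano at this aromatic carbon, para to a large group, gives the first clear sign in this assay that the choice of group here matters beyond a single small move: the change from methyl gives a 2.2-fold higher number from compound 3 to compound 4 (0.34 log units; beyond the scatter) and the change from fluoro gives a 4.6-fold higher number from compound 2 to compound 4 (0.66 log units; beyond the scatter) on the shared core. With three groups now compared at one place, the numbers rise in the order fluoro, methyl, cyano, and the step from fluoro to cyano is larger than a 2.1-fold higher number from compound 2 to compound 3 (0.32 log units; beyond the scatter) while remaining modest. The series holds no measurement that could explain this order.

Open, from the compounds shown here alone, is whether the rise belongs to cyano alone or whether other groups at this place, such as chloro, methoxy, an amine or a carboxylic acid, would extend the same order on the shared core. Also open, going by these compounds, is whether the order carries over to the core of compound 1, which has trifluoromethyl at the corresponding place but differs from the other compounds in more than one place.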